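A few compounds are considered here, and "the series" means these few. Any claim that something is new, unique, unknown or untested is made for them only; others in the source may bear on it.

Working notes on a small urea and amide set. Compound 1 `Cc1occc1C(=O)N1CCC(NC(=O)Nc2ccc(OC(F)(F)F)cc2)CC1`, compound 2 `CCOC(=O)N1CCC(NC(=O)Nc2ccc(OC(F)(F)F)c(F)c2)CC1` and compound 3 `CC(C)C(=O)N1CCC(CC(=O)Nc2ccc(OC(F)(F)F)c(F)c2)CC1` have been measured in a physicochemical assay for solubility, read by mass spectrometry, in phosphate buffer, with a stated time of 24 h, at pH 7.4; on this read-out lower numbers stand for lower solubility and higher numbers for higher solubility. Compound 1 gives 8.6 ug/mL, compound 2 gives 0.35 ug/mL and compound 3 gives 33 ug/mL. Compound 2 thus stands lowest of the three in this assay, compound 1 being its nearest neighbour and compound 3 the furthest, both gaps beyond the scatter. The next compound in line is compound 4 `O=C(Nc1ccc(OC(F)(F)F)c(F)c1)NC1CCN(C(=O)C2(C(F)(F)F)CC2)CC1`, not yet measured in this assay. It differs from compound 2 in one place: 1-(trifluoromethyl)cyclopropyl in place of ethoxy on a carbonyl carbon. Among the measured compounds shown here, no measured pair shows this change, so the size of the step rests on expectation alone. The expected step is a 1.2-fold lower number from compound 2 to compound 4 (0.07 log units; within the scatter), small and downward in this assay, or none beyond the scatter. Compound 4 is expected to give 0.3 ug/mL, within a range of 0.05 ug/mL to 2 ug/mL.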

Compound 4, solubility: 92 ug/mL
For compound 4 the middle estimate is 310-fold (2.49 log units) below the measured one; measured number above the stated range.
By their numbers in this assay, from the lowest: compound 2; then compound 1; then compound 3; then compound 4.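

The carbonyl carbon on the amide-type nitrogen in a ring proves highly sensitive: 1-(trifluoromethyl)cyclopropyl in place of ethoxy gives a 260-fold higher number from compound 2 to compound 4 (2.42 log units; beyond the scatter) in this assay on a single change. The earlier compounds shown here show no pair that isolates this position. Nothing measured here accounts for the size of the step.

Still open, from the compounds shown here alone, is whether the step follows the trifluoromethyl, the three-membered ring or the loss of the ethoxy oxygen. A plain cyclopropyl or a tert-butyl on the same carbonyl carbon would separate these readings.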